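A single substitution on compound 1

The source may hold more compounds than are shown below. What is called first, only, known or untested is meant among the compounds shown, and "the series" means these compounds.

Values in an ADME assay on HL-60 cells (Homo sapiens) for cytotoxicity, read by resazurin assay, with a stated time of 48 h, in the absence of a further agent (a lower number here means a stronger inhibitor, a higher number a weaker inhibitor), so far:
compound 1 `CN(Cc1cnc2nc(N)nc(NC(=O)OCc3ccc(B(O)O)cc3)c2n1)c1ccc(C(=O)N[C@@H](CCC(=O)O)C(=O)O)cc1` gives 40.3 nM
compound 2 `CN(Cc1cnc2nc(N)nc(N)c2n1)c1ccc(C(=O)N[C@@H](CCC(=O)N2CCSC2=O)C(=O)O)cc1` gives 40 nM
compound 3 `Nc1nc(N)c2nc(CN(Cc3ccc(B(O)O)cc3)c3ccc(C(=O)N[C@@H](CCC(=O)O)C(=O)O)cc3)cnc2n1` gives 7.5 nM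

Compound 1 shares the top of these three numbers with compound 2, the two lying within the scatter of each other, while compound 3 lies lower, beyond the scatter. Compound 4 `CN(Cc1cnc2nc(N)nc(NC(=O)OCc3ccccc3)c2n1)c1ccc(C(=O)N[C@@H](CCC(=O)O)C(=O)O)cc1` differs from compound 1 by a hydrogen atom in place of a group of 3 heavy atoms (1 boron, 2 oxygen; no ring), on an aromatic carbon on an otherwise unchanged structure. Going by the values given here, no measured pair isolates this change, so the expectation starts from compound 1 at 40.3 nM and remains uncertain. In this assay the expected change is a 3.0-fold higher number from compound 1 to compound 4 (0.47 log units; beyond the scatter) and points toward a weaker number, probably beyond the scatter. Compound 4 is estimated at 120 nM with an expected range of 35 nM to 500 nM in this measurement.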

Compound 4, half-maximal inhibitory concentration in the HL-60 assay: 1000 nM
The estimate for compound 4 lay 8.3-fold (0.92 log units) below the measured number; the measured number lies above the stated range.
By their numbers in the HL-60 assay, from the lowest: compound 3; then compounds 2 and 1 (each within the scatter of the next); then compound 4.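

Going by these compounds alone, on this aromatic carbon, para to a large group, the boron-bearing group matters more than the earlier compounds could show: in the HL-60 assay compound 1 gives 40.3 nM and compound 4 gives 1000 nM. In the HL-60 assay the replacement of that group by hydrogen gives a 25-fold higher number from compound 1 to compound 4 (1.39 log units; beyond the scatter). The same change also moves a physicochemical assay for activation, read by HPLC, in phosphate buffer, with a stated time of 24 h, at pH 7.4 (on this read-out higher numbers stand for a longer-lived compound and lower numbers for a shorter-lived compound), with an at least 82-fold higher number from compound 1 to compound 4 (1.91 log units; beyond the scatter), so the two read-outs shift together in this pair. In the physicochemical assay compound 1 gives 0.29 h. In the physicochemical assay compound 4 gives > 24 h, which is a limit of the assay, not a number: the limit of > 24 h in the physicochemical assay, at which 1 of the 2 values shown sits.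

A single pair cannot tie the two read-outs to each other. From the compounds shown here alone, whether a carboxylic acid or an amine on this carbon would preserve either number remains open.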